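This account rests on a few compounds, and the source may have more. Where it says the series, first, only, none or still open, it means among the compounds named here.

Measured so far:
compound 1, `CCCNc1nc(N)c(C(=O)N=C(N)N)nc1Cl`: 91%
compound 2, `NC(N)=NC(=O)c1nc(Cl)c(NC2CCCCC2)nc1N`: 92%

In an assay for inhibition of acid-sensing ion channel 3 (Homo sapiens), read by patch clamp, tested at 20 uM (a higher number here means more inhibition at the concentration tested (going by the name of the read-out), a lower number less inhibition), compound 2 gives 92% and compound 1 gives 91%; the two numbers lie within the scatter of each other, so compound 2 cannot be set apart from compound 1 on this evidence. Compound 3, `CN1CCN(c2nc(N)c(C(=O)N=C(N)N)nc2Cl)CC1`, is not yet measured in this assay. Against compound 2 the change is 4-methylpiperazin-1-yl in place of cyclohexylamino on an aromatic carbon.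

Within the data shown here, only one measured step bears on it: a number 1 percentage points higher from compound 1 to compound 2 (within the scatter), which swapped one alkyl group for another on the same nitrogen and left the read-out unchanged beyond the scatter. Among the measured compounds shown here, that shows the number stayed level when a larger group was put at this place, but no measured pair exchanges the cyclohexylamino for 4-methylpiperazin-1-yl, so the effect of that exchange is untested. A step of a number 14 percentage points lower from compound 2 to compound 3 (beyond the scatter) is expected, downward, with wide uncertainty. For compound 3 in this assay the estimate is 78%, between 50% and 95%.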

Compound 3, a percentage reported as inhibition, at one concentration (the size of the read-out at that concentration, not a potency): 51%
Beside the measured number, compound 3's estimate is 27 percentage points above it, and the stated range covers the measured number.
By their numbers in this assay, from the lowest: compound 3; then compounds 1 and 2 (each within the scatter of the next).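

In this assay, this aromatic carbon proves sensitive to the group it carries: the change to 4-methylpiperazin-1-yl gives a clear loss from either amine (a number 41 percentage points lower from compound 2 to compound 3 (beyond the scatter); a number 40 percentage points lower from compound 1 to compound 3 (beyond the scatter)). The earlier swap of propyl for cyclohexyl on the nitrogen left the read-out level (a number 1 percentage points higher from compound 1 to compound 2 (within the scatter)), and cyclohexylamino and 4-methylpiperazin-1-yl have the same count of heavy atoms, so that count does not separate compound 2 from compound 3. The exchange also removes the hydrogen-bond donor and adds a hetero atom to the ring, but nothing measured here ties the loss to either difference.

Going by these compounds, it remains open whether the loss follows the missing donor or the second ring nitrogen. Piperidin-1-yl, which lacks the donor but has no second ring nitrogen, would separate the two, and morpholin-4-yl would test a ring oxygen in that place.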